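Side-chain variation on the shared core in this assay

The source may report more compounds than this note shows. Statements on the series, on what has been measured and on what is new or still open speak of the compounds shown alone.

Measured so far:
compound 1, `CC(C)(C)c1ccc2ccccc2c1O`, 180 nM in an assay on RBL-1 cells with Polyunsaturated fatty acid 5-lipoxygenase (Rattus norvegicus) as the target; a higher number here means a weaker inhibitor, a lower number a stronger inhibitor
compound 2, `C=CCc1ccc2ccccc2c1O`, 56 nM
compound 3, `Cc1ccccc1Cc1ccc2ccccc2c1O`, 120 nM

Compound 2 gives the lowest number of the three; compound 3 sits above it and compound 1 further above it, both gaps beyond the scatter. Within the data shown here, the only one-place step measured, a 3.2-fold lower number from compound 1 to compound 2 (0.51 log units; beyond the scatter), shows that exchanging one side-chain for another on the core shifts the number by a modest amount.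

Compound 4, `Oc1c(Cc2ccncc2)ccc2ccccc12`, differs from compound 2 by pyridin-4-yl in place of vinyl on a saturated chain carbon bound to an aromatic carbon. Among the measured compounds shown here, no measured step covers this change. The nearest comparison is compound 3, which also carries an aromatic ring on the chain carbon bound to the core: compound 2 gives 56 nM and compound 3 gives 120 nM, a gap beyond the scatter.

On that basis compound 4 is expected to come in at 110 nM, with a range of 40 nM to 320 nM. The expected step is a 2.0-fold higher number from compound 2 to compound 4 (0.29 log units; within the scatter), a modest rise at the edge of the scatter.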

Compound 4, half-maximal inhibitory concentration: 140 nM
Compound 4: middle estimate off by 1.3-fold (0.10 log units), on the low side; low and high end bracket the measured number.
By their numbers in this assay, from the lowest: compound 2; then compounds 3, 4 and 1 (each within the scatter of the next).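

In this assay, among these compounds, the saturated chain carbon bound to the aromatic carbon was probed for the first time in a one-place step, and exchanging vinyl for pyridin-4-yl gives a 2.5-fold higher number from compound 2 to compound 4 (0.40 log units; beyond the scatter). The position therefore accepts a six-membered aromatic ring with one hetero atom and one hydrogen-bond acceptor at a modest cost, while vinyl keeps the lower number in this pair. No measurement at hand accounts for the size or direction of this step.

The compounds shown leave open how much of the step belongs to the ring and how much to its nitrogen, which an unsubstituted phenyl at this place would separate. They also leave open whether a longer chain, an amine or a carboxylic acid at this chain carbon would keep the number in this range.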